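A few compounds are considered here, and "the series" means these few. Any claim that something is new, unique, unknown or untested is made for them only; others in the source may bear on it.

Measured compounds:
compound 1, `COc1ccc(-c2ccc(C(=O)N[C@H](C)CCCc3cccnc3)cc2Br)cc1OC`, 180 nM
compound 2, `COc1ccc(-c2ccc(C(S)=N[C@H](C)CCCc3cccnc3)cc2)cc1OC`, 60 nM

In an assay (Canis lupus familiaris) for binding affinity to platelet-activating factor receptor (Homo sapiens), read by radioligand binding (on this read-out lower numbers stand for stronger inhibition and higher numbers for weaker inhibition), compound 1 gives 180 nM, the higher of the two numbers recorded; compound 2 gives 60 nM, and the gap between these two values lies beyond the scatter of the measurement. Going by the values given here, the two compounds differ in more than one place, so no single step connects them.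

Compound 3, `CCc1cc(C(=O)N[C@H](C)CCCc2cccnc2)ccc1-c1ccc(OC)c(OC)c1`, has not been measured in this assay. It differs from compound 1 in one place: ethyl in place of bromo on an aromatic carbon. The exchange keeps the count of hydrogen-bond donors and acceptors unchanged and brings in no ring or charge. Among the compounds with values here, with no comparable step among the measured compounds, the expectation for compound 3 rests on compound 1 alone, and the expected step of a 1.1-fold lower number from compound 1 to compound 3 (0.05 log units; within the scatter) is small and not beyond the scatter in either direction. Compound 3 is therefore estimated at 160 nM, within a range from 50 nM to 500 nM.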

Compound 3, half-maximal inhibitory concentration: 4 nM
The estimate for compound 3 lay 40-fold (1.60 log units) above the measured number; the measured number lies below the stated range.
By their numbers in this assay, from the lowest: compound 3; then compound 2; then compound 1.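

In this assay, the aromatic carbon ortho to a 3,4-dimethoxyphenyl group and meta to a large group turns out to be highly sensitive to its substituent: ethyl in place of bromo gives a 45-fold lower number from compound 1 to compound 3 (1.65 log units; beyond the scatter) in a single exchange. Going by these compounds alone, this is the first single-place step, and it shows a large change even though the exchange leaves the count of hydrogen-bond donors and acceptors unchanged and brings in no ring or charge. No measurement shown here accounts for the size of this step.

One pair cannot tell whether the lower number belongs to ethyl itself or would also appear with another group on this carbon, such as methyl, propyl or methoxy. As far as these compounds go, whether the step would hold with the amide of the shared core replaced also remains open.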